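Notes on the 3,4,5-trimethylpiperazin-1-yl step

A few compounds are considered here, and "the series" means these few. Any claim that something is new, unique, unknown or untested is made for them only; others in the source may bear on it.

Going by the values given here, in an ADME assay on microsomes from liver (Homo sapiens) for metabolic stability, read by LC-MS, with a stated time of 10 min (a higher number here means that more of the compound is left, a lower number that less of the compound is left), compound 2 (`CN(C[C@H]1Cc2c(cccc2N2CCNC(C)(C)C2)CN1)[C@H]1CCCc2cccnc21`) gives 100%, the highest number so far, although compound 3 (`CN(C[C@H]1Cc2c(cccc2N2CCN(c3cccc(C(F)(F)F)c3)CC2)CN1)[C@H]1CCCc2cccnc21`) at 90.3% lies within the scatter of it. Compound 1 (`CN(C[C@H]1Cc2c(cccc2N2CCN(C3CC3)CC2)CN1)[C@H]1CCCc2cccnc21`) gives 15.5%, well apart from both: the series shows a number 84.5 percentage points higher from compound 1 to compound 2 (beyond the scatter), and also a number 74.8 percentage points higher from compound 1 to compound 3 (beyond the scatter).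

Compound 4 (`C[C@@H]1CN(c2cccc3c2C[C@H](CN(C)[C@H]2CCCc4cccnc42)NC3)C[C@H](C)N1C`) changes the same group on the shared core: 3,4,5-trimethylpiperazin-1-yl in place of 3,3-dimethylpiperazin-1-yl on an aromatic carbon. Among the compounds with values here, no measured step covers this exact change. The two large steps bear on it only indirectly, since the entering group carries a methyl on an amine nitrogen in a ring, where compound 1 carries cyclopropyl and compound 3 carries 3-(trifluoromethyl)phenyl. These two substituted cases diverge, with 15.5% for compound 1 and 90.3% for compound 3, so the outcome is poorly fixed. With 100% for compound 2, the number can hardly rise. The expected change is a moderate fall, a number 38 percentage points lower from compound 2 to compound 4 (beyond the scatter). For compound 4 the estimated value in this assay is 62%, with an expected range of 28% to 96%.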

Compound 4, percent of the compound remaining: 24.6%
The estimate for compound 4 lay 37.4 percentage points above the measured number, outside the stated range (below it).
By their numbers in this assay, from the lowest: compounds 1 and 4 (each within the scatter of the next); then compounds 3 and 2 (each within the scatter of the next).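

In this assay the 3,4,5-trimethylpiperazin-1-yl group on this aromatic carbon gives a number 75.4 percentage points lower from compound 2 to compound 4 (beyond the scatter), so the high number of the 3,3-dimethylpiperazin-1-yl group does not carry over to this closely related piperazine. Against the 4-cyclopropylpiperazin-1-yl group the same replacement gives a number 9.1 percentage points higher from compound 1 to compound 4 (within the scatter), which places these two groups together, and a low number now goes with a small alkyl substituent on the ring amine nitrogen in compound 1 and compound 4, while compound 3, with 3-(trifluoromethyl)phenyl on that nitrogen, goes against this at 90.3%. Nothing at hand accounts for the fall.

The compounds shown do not separate the methyl on the ring amine nitrogen from the methyls on the ring carbons. Also open, on these data alone, is how an acetyl group or a hydroxyethyl chain on that nitrogen would read.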